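This account rests on a few compounds, and the source may have more. Where it says the series, first, only, none or still open, it means among the compounds named here.

Working notes on the series in a functional assay on PC-3 cells (Homo sapiens) for cytotoxicity, read by MTT assay, with a stated time of 72 h; a higher number here means a weaker inhibitor of growth, a lower number a stronger inhibitor of growth. Of the compounds shown here, three have been measured so far. Compound 1 `C[Se]c1nc2ccccc2s1` gives only a limit of this assay, > 100000 nM, and not a number. Compound 2 `N#CSc1nccc(Cl)n1` likewise gives a limit, > 100000 nM. Among the compounds with values here, compound 3 `O=C1c2ccccc2C(=O)N1CS` is the only compound of the three with a numerical value, 74700 nM in this assay; it therefore stands apart from the other two, which sit at the limit of > 100000 nM in this assay, at which 2 of the 3 values shown sit, and no ordering among the three beyond that can be stated. Within the data shown here, no pair of measured compounds differs in a single place, so no measured step is available as a guide.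

Compound 4 `O=C1c2ccccc2C(=O)N1C[SeH]` is the next compound, not yet measured. It differs from compound 3 by one selenium atom in place of one sulfur atom, on a saturated chain carbon bound to an amide-type nitrogen in a ring. Among the measured compounds shown here, with no measured step to lean on, the expected step of a 1.2-fold lower number from compound 3 to compound 4 (0.10 log units; within the scatter) is taken as none beyond the usual scatter. For compound 4 the value in this assay is accordingly expected near 60000 nM, with a range from 25000 nM to 150000 nM.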

Compound 4, concentration for 50% growth inhibition: 6400 nM
The estimate for compound 4 lay 9.4-fold (0.97 log units) above the measured number; measured number outside the range, below it.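

In this assay, one selenium atom in place of one sulfur atom, on a saturated chain carbon bound to an amide-type nitrogen in a ring, gives a 12-fold lower number from compound 3 to compound 4 (1.07 log units; beyond the scatter). Within the data shown here, this is the first single-place comparison, and it shows that this position responds strongly to the identity of this one atom while the rest of the structure stays the same. Nothing measured here accounts for the size of the step.

Open, as far as these compounds go, is how an amine, a hydroxyl group or a longer chain at this place would compare with the sulfanyl group of compound 3 and the selenium-bearing group of compound 4. Also open, from the compounds shown here alone, is whether the same exchange gives a step of similar size on a different core.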